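Switching the exocyclic substituent on a fused dihydropyridine core

The source may report more compounds than this note shows. Statements on the series, on what has been measured and on what is new or still open speak of the compounds shown alone.

Measured compounds:
- Compound 1, `CC1(C)CC(=O)C2=C(C1)N(c1ccc(S(N)(=O)=O)cc1)C(N)=C(C#N)C2c1ccc(Cl)cc1`, gives 72900 nM in a functional assay on MCF7 cells (Homo sapiens) for antiproliferative activity, read by sulforhodamine B assay, with a stated time of 48 h; a lower number here means a stronger inhibitor, a higher number a weaker inhibitor.
- Compound 2, `CCO/C=N/C1=C(C#N)C(c2ccc(Cl)cc2)C2=C(CC(C)(C)CC2=O)N1c1ccc(S(N)(=O)=O)cc1`, gives 97200 nM in this assay.
- Compound 3, `CC1(C)CC(=O)C2=C(C1)N(c1ccc(S(N)(=O)=O)cc1)C(NC(=O)CCl)=C(C#N)C2c1ccc(Cl)cc1`, gives 84300 nM in this assay.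

All three share one core and differ only in the group on a double-bonded ring carbon. Compound 2 carries the highest number of the three, yet its gaps to the others are within the scatter: a 1.2-fold lower number from compound 2 to compound 3 (0.06 log units; within the scatter) and, seen from compound 1, a 1.3-fold higher number from compound 1 to compound 2 (0.12 log units; within the scatter). The third pair behaves the same way: a 1.2-fold higher number from compound 1 to compound 3 (0.06 log units; within the scatter).

Compound 4, `CC1(C)CC(=O)C2=C(C1)N(c1ccc(S(N)(=O)=O)cc1)C(N1C(=O)CCC1=O)=C(C#N)C2c1ccc(Cl)cc1`, takes the step from compound 2 by a group of 7 heavy atoms (4 carbon, 1 nitrogen, 2 oxygen; one five-membered non-aromatic ring with 1 hetero atom) in place of a group of 5 heavy atoms (3 carbon, 1 nitrogen, 1 oxygen; no ring), on a double-bonded ring carbon. The three measured steps all change this same position, and none moved the number beyond the scatter; there is therefore no basis for expecting a shift here either. The step from compound 2 to compound 4 is estimated as a 1.1-fold lower number from compound 2 to compound 4 (0.06 log units; within the scatter). Compound 4 is expected to give about 85000 nM in this assay, within 40000 nM to 180000 nM.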

Compound 4, half-maximal inhibitory concentration: 95200 nM
Beside the measured number, compound 4's estimate is 1.1-fold (0.05 log units) below it, and the stated range covers the measured number.
By their numbers in this assay, from the lowest: compounds 1, 3, 4 and 2 (each within the scatter of the next).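

Going by these compounds alone, replacing the open groups with a ring at this position, the 2,5-dioxopyrrolidin-1-yl group, still gives no step that can be told from the scatter in this assay: there is a 1.0-fold lower number from compound 2 to compound 4 (0.01 log units; within the scatter) and a 1.1-fold higher number from compound 3 to compound 4 (0.05 log units; within the scatter) and a 1.3-fold higher number from compound 1 to compound 4 (0.12 log units; within the scatter) in these comparisons. Among these four compounds, then, neither the open groups nor this ring separate one compound from another, though all four numbers are high, so the flat result holds only for this weakly inhibiting set. No measurement is available to explain this lack of difference.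

As far as these compounds go, all four groups are joined to the ring carbon through nitrogen, so it remains open whether a group joined through carbon, such as a carboxylic acid or a phenyl ring, would move the number beyond the scatter. From the compounds shown here alone, it is also open whether this position would stay as silent if a 4-methoxyphenyl group replaced the 4-chlorophenyl group.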